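Removing Difluoromethoxy from Compound 1: Expected Cytotoxicity

This account rests on a few compounds, and the source may have more. Where it says the series, first, only, none or still open, it means among the compounds named here.

In a functional assay on HepG2 cells (Homo sapiens) for cytotoxicity, read by MTT assay, with a stated time of 48 h (on this read-out lower numbers stand for stronger inhibition and higher numbers for weaker inhibition), compound 1 `O=S(=O)(CCC(F)=C(F)F)c1nc2ccc(OC(F)F)cc2[nH]1` reaches only a limit, > 120000 nM. Compound 2 `O=S(=O)(CCC(F)=C(F)F)c1ccccn1` likewise returns a limit in this assay, > 120000 nM. Both results sit at the same point, (the limit of > 120000 nM in this assay, at which 2 of the 2 values shown sit), so compound 1 stands together with the other value rather than apart from it. Compound 3 `O=S(=O)(CCC(F)=C(F)F)c1nc2ccccc2[nH]1` differs from compound 1 by hydrogen in place of difluoromethoxy on an aromatic carbon. Going by the values given here, no measured step exists to size this change; in this assay the expected step is none beyond the scatter, with compound 3 most likely again returning a limit. The estimate for compound 3 in this assay is 150000 nM, spanning 60000 nM to 400000 nM, a step that the limit leaves unreadable from compound 1 to compound 3.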

Compound 3, half-maximal inhibitory concentration: > 120000 nM
Compound 3: a limit, no number; the forecaster's own chance of this, stated with the estimate: 85%; the middle value lies beyond the limit too.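

Going by these compounds alone, compound 3, like compound 1, returns only a limit, so no step between the two can be read: the limit of > 120000 nM in this assay, at which 3 of the 3 values shown sit. The compounds shown leave open whether any of them would give an actual number in this assay.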